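Methylsulfanyl in place of methoxy on compound 2

The source may report more compounds than this note shows. Statements on the series, on what has been measured and on what is new or still open speak of the compounds shown alone.

In a functional assay on the whole organism with Canis familiaris (Canis lupus familiaris) as the target (a higher number here means that more compound is needed for the effect, a lower number that less compound is needed), compound 2 (`CCCOc1cc(OC)ccc1-c1nc2cc[nH]cc-2n1`) gives 1.3 mg/kg. Among the measured compounds shown here, that is the higher of the two numbers so far, and the gap lies beyond the scatter from compound 1 (`COc1cc(SC)ccc1-c1nc2cc[nH]cc-2n1`), which gives 0.2 mg/kg. Compound 3 (`CCCOc1cc(SC)ccc1-c1nc2cc[nH]cc-2n1`) keeps the propoxy group of compound 2 but has methylsulfanyl in place of methoxy on an aromatic carbon. For the measured compounds named here, no step in a single place has been measured in this assay. Compound 1 also carries methylsulfanyl and gives 0.2 mg/kg, so a moderately lower number is expected. The expected change is a 2.2-fold lower number from compound 2 to compound 3 (0.34 log units; beyond the scatter). For compound 3 the estimated value is 0.6 mg/kg, within an expected range of 0.2 mg/kg to 1.8 mg/kg.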

Compound 3, dose for half-maximal effect: 1.2 mg/kg
For compound 3 the middle estimate is 2.0-fold (0.30 log units) below the measured one; the measured number falls inside the stated range.
By their numbers in this assay, from the lowest: compound 1; then compounds 3 and 2 (each within the scatter of the next).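

In this assay, methylsulfanyl in place of methoxy on an aromatic carbon, with the propoxy group kept, gives a 1.1-fold lower number from compound 2 to compound 3 (0.03 log units; within the scatter), so this exchange does not separate the two compounds. With methylsulfanyl held in place, ethyl in place of hydrogen on the chain carbon bound to the oxygen gives a 6.0-fold higher number from compound 1 to compound 3 (0.78 log units; beyond the scatter), which is the step that lies beyond the scatter here. No measurement offered bears on the cause of either step. The compounds leave open whether the exchange at this position would also be silent with methoxy in place of propoxy. They also leave open how an ethoxy or butoxy chain, or an amine at the methylsulfanyl position, would read.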